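The source may hold more compounds than are shown below. What is called first, only, known or untested is meant among the compounds shown, and "the series" means these compounds.

Within the data shown here, compound 2 `COc1ccc2nc(NC(=O)c3cn(-c4ccccc4)nc3-c3ccc(Cl)cc3)sc2c1` gives 31400 nM in a functional assay on A549 cells (Homo sapiens) for cytotoxicity, read by MTT assay, with a stated time of 72 h (a higher number here means a weaker inhibitor, a lower number a stronger inhibitor), the higher of the two numbers so far. Compound 1 `O=C(Nc1nc2ccc(F)cc2s1)c1cn(-c2ccccc2)nc1-c1ccc(Cl)cc1` gives 8860 nM. Among the measured compounds shown here, the only measured step, a 3.5-fold higher number from compound 1 to compound 2 (0.55 log units; beyond the scatter), concerns a different exchange at the same place. Compound 3 `Cc1ccc2nc(NC(=O)c3cn(-c4ccccc4)nc3-c3ccc(Cl)cc3)sc2c1` differs from compound 2 by methyl in place of methoxy on an aromatic carbon. For the measured compounds named here, no measured step swaps methyl for methoxy, so the direction is uncertain, and a change of similar size or none beyond the scatter is both plausible. Compound 3 is expected to give 20000 nM, within a range of 7000 nM to 60000 nM. This estimate corresponds to an expected 1.6-fold lower number from compound 2 to compound 3 (0.20 log units; within the scatter).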

Compound 3, half-maximal inhibitory concentration: 18600 nM
Beside the measured number, compound 3's estimate is 1.1-fold (0.03 log units) above it; the range from low to high includes it.
By their numbers in this assay, from the lowest: compound 1; then compounds 3 and 2 (each within the scatter of the next).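

At this position, methyl in place of methoxy gives a 1.7-fold lower number from compound 2 to compound 3 (0.23 log units; within the scatter) in this assay and so does not separate the two compounds beyond repeat-measurement noise. Methyl in place of fluoro gives a 2.1-fold higher number from compound 1 to compound 3 (0.32 log units; beyond the scatter) and so, of the three groups, fluoro keeps the lowest number, though the margin over methyl is modest. Nothing available explains these differences.

The compounds shown leave open how an amine, a carboxylic acid or a longer chain at this position would read.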